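Isopropyl on the anilino ring of a chloropyrimidine series

This account rests on a few compounds, and the source may have more. Where it says the series, first, only, none or still open, it means among the compounds named here.

Compound 1 `Cc1ccccc1Nc1nc(NCc2ccco2)ncc1Cl` carries a furanylmethylamino group on the shared core. In a functional assay on MCF7 cells (Homo sapiens) for inhibition, read by CCK-8 assay, with a stated time of 48 h (a lower number here means a stronger inhibitor of growth, a higher number a weaker inhibitor of growth), compound 1 gives only a limit, > 100000 nM, and not a number; this is the limit of > 100000 nM in this assay, at which 1 of the 2 values shown sits. Compound 2 `CN1CCN(c2ccc(Nc3ncc(Cl)c(Nc4ccccc4)n3)nc2)CC1` replaces that group with an aminopyridine bearing methylpiperazine and keeps a plain anilino group. In this assay, within the data shown here, compound 2 gives 51800 nM, the only number in the set so far. Compound 3 `CC(C)c1ccc(Nc2nc(Nc3ccc(N4CCN(C)CC4)cn3)ncc2Cl)cc1` differs from compound 2 by isopropyl in place of hydrogen on an aromatic carbon, that is anilino to (4-isopropylphenyl)amino on the same core. Among the measured compounds shown here, no measured pair in the set mirrors this change, so its size is untested here. The step from compound 2 to compound 3 is expected to be a 1.7-fold lower number from compound 2 to compound 3 (0.24 log units; within the scatter), a modest gain at most. Compound 3 is estimated at 30000 nM in this assay, within 8000 nM to 100000 nM.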

Compound 3, concentration for 50% growth inhibition: 1880 nM
Compound 3: the middle estimate sits 16-fold (1.20 log units) above what was measured; measured number below the stated range.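

Isopropyl in place of hydrogen, on an aromatic carbon para to a large group, gives a 28-fold lower number from compound 2 to compound 3 (1.44 log units; beyond the scatter) in this assay. This position on the anilino ring therefore responds strongly to substitution, at least in this one pair: an all-carbon group without a ring, counted with no hydrogen-bond donors or acceptors, moves the read-out well beyond the scatter. Nothing among the measurements shown accounts for the size of this step.

On these data alone, whether the step belongs to isopropyl itself or would also appear with a methyl, a tert-butyl or a carboxylic acid at this place remains open. Also open, as far as these compounds go, is whether isopropyl would act alike alongside the furanylmethylamino group of compound 1, whose > 100000 nM is a limit and not a number.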